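The source may hold more compounds than are shown below. What is called first, only, known or untested is meant among the compounds shown, and "the series" means these compounds.

Among the measured compounds shown here, compound 1 `CCc1cccc(NC(=O)CN2CCC(c3cccc[n+]3[O-])CC2)c1` is one of three compounds measured in a functional assay on HEK293 cells for agonist activity at D(4) dopamine receptor (Homo sapiens), read by FLIPR; on this read-out lower numbers stand for an effect already at smaller amounts and higher numbers for an effect only at larger amounts of compound. Compound 1 gives 95 nM, the highest of the three numbers. Compound 3 `Cc1cccc(C(=O)NCN2CCC(c3cccc[n+]3[O-])CC2)c1` gives 89 nM, a number lying within the scatter of that of compound 1, while compound 2 `Cc1cccc(C(=O)NCN2CCC(c3nccs3)CC2)c1` gives 9.8 nM, a number clearly lower than that of compound 1. For the measured compounds named here, the single measured step, a 9.1-fold higher number from compound 2 to compound 3 (0.96 log units; beyond the scatter), concerns the group on a saturated ring carbon and leaves the amide side of the shared core untouched. Compound 4 `O=C(CN1CCC(c2cccc[n+]2[O-])CC1)Nc1ccccc1F` differs from compound 1 in another place: 2-fluorophenyl in place of 3-ethylphenyl on an amide-type nitrogen. Going by the values given here, no measured step touches the group on the amide-type nitrogen, so nothing among the three numbers speaks directly to this change, and the step is expected to stay within the scatter in this assay. Compound 4 is therefore estimated at 100 nM, with a range from 30 nM to 330 nM. The expected step of a 1.1-fold higher number from compound 1 to compound 4 (0.02 log units; within the scatter) is accordingly small.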

Compound 4, half-maximal effective concentration: 270 nM
Compound 4: middle estimate off by 2.7-fold (0.43 log units), on the low side; the measured number falls inside the stated range.
By their numbers in this assay, from the lowest: compound 2; then compounds 3 and 1 (each within the scatter of the next); then compound 4.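

In this assay, the group on the amide-type nitrogen proves able to move the read-out: 2-fluorophenyl in place of 3-ethylphenyl gives a 2.8-fold higher number from compound 1 to compound 4 (0.45 log units; beyond the scatter). Among the compounds shown here, this is the first measured step at this place, as the earlier step concerned only the group on a saturated ring carbon, and it shows that this nitrogen's substituent matters with the rest of compound 1 held constant. Nothing available explains the rise in the number.

The step replaces ethyl with fluorine and changes the substituent's numbered place at once, so the compounds shown cannot separate these two changes. From the compounds shown here alone, it also remains open where an unsubstituted phenyl or a 2-ethylphenyl group on this nitrogen would fall, and whether the same exchange would have a similar effect on the core of compound 2.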